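Cyclopentyl for Isopropyl on the Chloro Analogue

The source may hold more compounds than are shown below. What is called first, only, known or untested is meant among the compounds shown, and "the series" means these compounds.

Compound 1 `Cc1ccccc1-c1nnc(NNC(C)C)s1` and compound 3 `CC(C)NNc1nnc(-c2ccccc2Cl)s1` share one core and differ in a single spot: chloro in place of methyl on an aromatic carbon. In a functional assay on the whole organism with Mus musculus as the target, in the maximal electroshock model, with a stated time of 1 h (a higher number here means that more compound is needed for the effect, a lower number that less compound is needed), compound 1 gives 83 mg/kg. In this assay compound 3 gives 50 mg/kg, a step of a 1.7-fold lower number from compound 1 to compound 3 (0.22 log units; within the scatter).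

Compound 2 `Cc1ccccc1-c1nnc(NNC2CCCC2)s1` arises from compound 1 through (cyclopentyl in place of isopropyl on an amine nitrogen). In this assay compound 2 reaches only a limit of the assay, > 100 mg/kg. That step reads an at least 1.2-fold higher number from compound 1 to compound 2 (0.08 log units; that floor lies within the scatter), resting on (the limit of > 100 mg/kg in this assay, at which 1 of the 3 values shown sits).

Compound 4 `Clc1ccccc1-c1nnc(NNC2CCCC2)s1` carries the same change on the core of compound 3: cyclopentyl in place of isopropyl on an amine nitrogen. Compound 4 is expected to move by a 2.0-fold higher number from compound 3 to compound 4 (0.30 log units; within the scatter) in this assay, a guess that rests on compound 2, whose step is an at least 1.2-fold higher number from compound 1 to compound 2 (0.08 log units; that floor lies within the scatter). In this assay compound 4 is therefore estimated at 100 mg/kg, somewhere between 55 mg/kg and 200 mg/kg, with a fair chance that only a limit is reported.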

Compound 4, dose for half-maximal effect: > 100 mg/kg
Compound 4: no number, only a limit; the forecaster's own chance of this, stated with the estimate: 55%; the middle value lies on the limit itself.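

With cyclopentyl in place of isopropyl on the core of compound 3, this assay gives an at least 2.0-fold higher number from compound 3 to compound 4 (0.30 log units; that floor lies within the scatter), and this step rests on a limit of the assay: the limit of > 100 mg/kg in this assay, at which 2 of the 4 values shown sit.

The same change on the two cores therefore cannot be given a size, so nothing can be said about whether it carries over unchanged: the same change on two cores in this assay, an at least 1.2-fold higher number (0.08 log units; that floor lies within the scatter) from compound 1 to compound 2 and an at least 2.0-fold higher number (0.30 log units; that floor lies within the scatter) from compound 3 to compound 4; the limit leaves it open whether they differ

What the data do show is that compound 2 and compound 4, the two cyclopentyl compounds, both end at that limit, and the step between them cannot be read.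

The compounds shown leave open how far beyond the limit either one lies. They also leave open whether an ethyl or a cyclohexyl group on that amine nitrogen would return a number rather than a limit.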